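This account rests on a few compounds, and the source may have more. Where it says the series, first, only, none or still open, it means among the compounds named here.

Measured so far in a functional assay on MDA-MB-468 cells (Homo sapiens) for cytotoxicity, read by sulforhodamine B assay, with a stated time of 48 h; a lower number here means a stronger inhibitor of growth, a higher number a weaker inhibitor of growth:
compound 1 `Cc1ccc2nc(/N=C3\C(=O)N(CN4CCCCC4)c4cccc(Br)c43)sc2c1` gives 24000 nM
compound 2 `O=C1C(=O)N(CN2CCCCC2)c2cccc(Cl)c21` gives 82800 nM
compound 3 `Cc1ccc2nc(/N=C3\C(=O)N(CN4CCCCC4)c4cccc(Cl)c43)sc2c1` gives 19800 nM

Compound 1 stands second highest of the three numbers in this assay; compound 3 lies nearest to it and compound 2 furthest. Within the data shown here, the only step measured between two compounds that differ in a single place is a 1.2-fold lower number from compound 1 to compound 3 (0.08 log units; within the scatter), a halogen exchange that lies within the scatter. Compound 2 differs from compound 1 in more than one place, so only the two values can be set side by side: compound 2 gives the higher number of the two, beyond the scatter.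

Compound 4 `CCN(CC)CN1C(=O)/C(=N\c2nc3ccc(C)cc3s2)c2c(Br)cccc21` differs from compound 1 by diethylamino in place of piperidin-1-yl on a saturated chain carbon bound to an amide-type nitrogen in a ring. Among the measured compounds shown here, no measured step touches that part of the shared core; the one measured step, from compound 1 to compound 3, sits on the aromatic ring and was within the scatter. Nothing in the measured set therefore points to a step beyond the scatter in either direction. The expected step is a 1.1-fold higher number from compound 1 to compound 4 (0.03 log units; within the scatter), and compound 4 is estimated at 26000 nM, with a range from 11000 nM to 60000 nM.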

Compound 4, concentration for 50% growth inhibition: 43100 nM
For compound 4 the middle estimate is 1.7-fold (0.22 log units) below the measured one, and the stated range covers the measured number.
By their numbers in this assay, from the lowest: compounds 3, 1, 4 and 2 (each within the scatter of the next, the first and the last beyond it).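

this assay The first measured change at this position, on a saturated chain carbon bound to an amide-type nitrogen in a ring, gives a 1.8-fold higher number from compound 1 to compound 4 (0.25 log units; within the scatter) and so extends the reading beyond the aromatic halogen exchange. In this pair, replacing the six-membered non-aromatic ring of piperidin-1-yl with the ring-free diethylamino group does not move the number beyond the scatter, so this one pair gives no sign that the ring is required for growth inhibition. No available evidence bears on the reason for this result.

Still open, going by these compounds, is whether morpholin-4-yl, or a longer chain carrying the amine, would also remain within the scatter of compound 1. Also open, on these data alone, is whether diethylamino in place of piperidin-1-yl reads the same on the chloro compound 3.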